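Replacing the halophenyl amine with a piperidinylmethyl group

A few compounds are considered here, and "the series" means these few. Any claim that something is new, unique, unknown or untested is made for them only; others in the source may bear on it.

Measured so far:
compound 1 `CCN1CCc2c(sc(NC(=O)Nc3ccc(Br)cc3)c2C(N)=O)C1` – 3130 nM
compound 2 `CCN1CCc2c(sc(NC(=O)Nc3ccc(I)cc3)c2C(N)=O)C1` – 1620 nM
compound 3 `CCN1CCc2c(sc(NC(=O)Nc3ccc(C(F)(F)F)cc3)c2C(N)=O)C1` – 2910 nM

For the measured compounds named here, in a functional assay (strain AB) with Danio rerio as the target, read by microscopy, with a stated time of 1 h (on this read-out higher numbers stand for an effect only at larger amounts of compound and lower numbers for an effect already at smaller amounts), compound 2 gives 1620 nM, the lowest of the three numbers, but the gaps a 1.9-fold lower number from compound 1 to compound 2 (0.29 log units; within the scatter) and a 1.8-fold higher number from compound 2 to compound 3 (0.25 log units; within the scatter) both lie within the scatter, so no compound can be called the most potent. Compound 4 `CCN1CCc2c(sc(NC(=O)CN3CCCCC3)c2C(N)=O)C1` differs from compound 2 in one place: (piperidin-1-yl)methyl in place of (4-iodophenyl)amino on a carbonyl carbon. The measured steps, including a 1.1-fold lower number from compound 1 to compound 3 (0.03 log units; within the scatter), only exchange one small group for another on the aromatic ring and all stay within the scatter; none removes the ring and its attached nitrogen, so they bear little on this change. With a change this large, a clearly higher number is expected, a 6.2-fold higher number from compound 2 to compound 4 (0.79 log units; beyond the scatter). Compound 4 is estimated at 10000 nM, with a range from 2000 nM to 50000 nM.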

Compound 4, half-maximal effective concentration: > 25000 nM
Compound 4: a limit, no number; the forecaster's own chance of this, stated with the estimate: 30%; at least 2.5-fold (0.39 log units) between middle value and limit.
By their numbers in this assay, from the lowest: compounds 2, 3 and 1 (each within the scatter of the next). At a limit, above all of these: compound 4.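

Putting (piperidin-1-yl)methyl on the carbonyl carbon gives an at least 15-fold higher number from compound 2 to compound 4 (1.18 log units; beyond the scatter) and an at least 7.9-fold higher number from compound 1 to compound 4 (0.90 log units; beyond the scatter) in this assay. For compound 4 the value is a limit of the assay, not a number: the limit of > 25000 nM in this assay, at which 1 of the 4 values shown sits. The earlier swaps on the aromatic ring all stayed within the scatter, whereas this position responds strongly when the whole (4-halophenyl)amino group is exchanged.

As far as these compounds go, this change removes the aromatic ring and the hydrogen-bond donor together, so which of them matters stays open. Also open, from the compounds shown here alone, is how a benzyl group or a diethylamino-methyl chain on that carbonyl carbon would behave.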